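Aryl substitution on the chain carbon: compound 3

This account rests on a few compounds, and the source may have more. Where it says the series, first, only, none or still open, it means among the compounds named here.

Going by the values given here, compound 2 `CCOC(=O)C(C(=O)OCC)C(CC(=O)C[C@@H]1O[C@H](CO)[C@@H](O)[C@H](O)[C@H]1O)c1ccccc1` stands lowest of the two numbers measured so far in an assay on isolated protein for inhibition of lysosomal alpha-glucosidase (Rattus norvegicus), tested at 100 uM; on this read-out lower numbers stand for less inhibition and higher numbers for more inhibition at the one concentration tested (going by the name of the read-out); compound 2 gives -45%. Among the compounds with values here, its nearest neighbour, compound 1 `CCOC(=O)C(C(=O)OCC)C(CC(=O)C[C@@H]1O[C@H](CO)[C@@H](O)[C@H](O)[C@H]1O)c1ccc(Cl)cc1`, gives -10% in this assay, and the single measured step between them, a number 35 percentage points lower from compound 1 to compound 2 (beyond the scatter), is the only guide to changes on the aromatic ring. Compound 3 `CCOC(=O)C(C(=O)OCC)C(CC(=O)C[C@@H]1O[C@H](CO)[C@@H](O)[C@H](O)[C@H]1O)c1ccc(OC)c(OC)c1` carries 3,4-dimethoxyphenyl in place of phenyl on a saturated chain carbon bound to two saturated chain carbons. No measured step covers a methoxy group or two substituents on the ring at once; the one step that touches the ring at all removed a chloro group and was large, as shown by a number 35 percentage points lower from compound 1 to compound 2 (beyond the scatter). Restoring substituents to the ring is therefore expected to move the number upward, but by an uncertain amount, since the entering group is not the one that left in the measured step. The expected step is a number 25 percentage points higher from compound 2 to compound 3 (beyond the scatter), estimated to be moderate and possibly within the scatter. Compound 3 is accordingly estimated at -20% in this assay, with a range from -50% to 15%.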

Compound 3, a percentage reported as inhibition, at one concentration (the size of the read-out at that concentration, not a potency): -2.3%
For compound 3 the middle estimate is 17.7 percentage points below the measured one; measured number inside the range.
By their numbers in this assay, from the lowest: compound 2; then compounds 1 and 3 (each within the scatter of the next).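

In this assay the aryl group on a saturated chain carbon bound to two saturated chain carbons now has a second substituted example. Here 3,4-dimethoxyphenyl in place of phenyl gives a number 42.7 percentage points higher from compound 2 to compound 3 (beyond the scatter) and shows that a large step at this position is not confined to the chloro group of the earlier pair. Set against 4-chlorophenyl, the same group gives a number 7.7 percentage points higher from compound 1 to compound 3 (within the scatter) and leaves the two substituted rings indistinguishable in this read-out, so that among the compounds shown only the unsubstituted phenyl of compound 2 stands apart. No measurement at hand explains why the unsubstituted ring differs from both substituted rings.

Still open, as far as these compounds go, is whether a single methoxy group on the ring would match the step seen with the 3,4-dimethoxyphenyl group, and whether a ring bearing an amine or a carboxylic acid would follow the same trend. Also open, from the compounds shown here alone, is whether any aryl group at this position can carry the number clearly above zero at the one concentration tested.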